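Ethylcarbamoyl in Place of Propylcarbonyl: Compound 2 to Compound 4

The compounds below may be only part of what the source reports. "The series", "measured", "known", "first", "only" and "open" are said of these compounds alone.

Compound 1, `CCCC(=O)Nc1cccc(S(=O)(=O)Oc2ccccc2C(C)C)c1`, gives 9400 nM in a functional assay on MCF7 cells (Homo sapiens) for antiproliferative activity, read by sulforhodamine B assay, with a stated time of 48 h; a lower number here means a stronger inhibitor, a higher number a weaker inhibitor.
Compound 2, `CCCC(=O)Nc1ccc(S(=O)(=O)Oc2ccccc2C(C)C)cc1`, gives 6600 nM in this assay.
Compound 3, `CCCC(=O)Nc1ccc(S(=O)(=O)Oc2ccccc2I)cc1`, gives 9700 nM in this assay.

The three numbers sit close together. Among the measured compounds shown here, the values of compound 1 and compound 2 differ by less than the usual scatter, and the step of a 1.5-fold higher number from compound 2 to compound 3 (0.17 log units; within the scatter) is likewise within the scatter, so no compound among the three can be set apart from the others.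

The new compound is compound 4, `CCNC(=O)Nc1ccc(S(=O)(=O)Oc2ccccc2C(C)C)cc1`. It differs from compound 2 in one place: ethylamino in place of propyl on a carbonyl carbon. The shared core of compound 2 and compound 4 is otherwise unchanged.

Of the measured steps, only a 1.5-fold higher number from compound 2 to compound 3 (0.17 log units; within the scatter) exists, and it touches the other end of the molecule, the isopropyl on the aromatic carbon, not the propylcarbonyl amino group. For the measured compounds named here, no measured step alters that group. The data therefore give no direct guide to the size or direction of the step in this assay.

With nothing to point either way, compound 4 is expected to stay near compound 2, with a step of a 1.1-fold higher number from compound 2 to compound 4 (0.03 log units; within the scatter) that is estimated, not observed. Compound 4 is estimated at 7000 nM, with a range from 2500 nM to 20000 nM.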

Compound 4, half-maximal inhibitory concentration: 10000 nM
Compound 4: middle estimate off by 1.4-fold (0.15 log units), on the low side; the range from low to high includes it.
By their numbers in this assay, from the lowest: compounds 2, 1, 3 and 4 (each within the scatter of the next).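

Compound 1, compound 2 and compound 3 all carry the propylcarbonyl group, so they say nothing about this position; the exchange of propyl for ethylamino on a carbonyl carbon now gives a first reading there, with a 1.5-fold higher number from compound 2 to compound 4 (0.18 log units; within the scatter) in this assay. The change turns the (propylcarbonyl)amino group into the (ethylcarbamoyl)amino group, keeping the count of heavy atoms while adding one hydrogen-bond donor and a nitrogen, and in this single pair that exchange leaves the number within the scatter. No measurement available here bears on the reason for this outcome, so the step stands as an observation without an explanation.

From the compounds shown here alone, whether this position stays as undemanding with other groups on the carbonyl carbon remains open, for example a methyl, a longer chain such as hexyl, a dimethylamino group or a morpholine. Also open, going by these compounds, is whether ethylamino in place of propyl would read the same way on the core of compound 1 or with the iodo group of compound 3, since the exchange is seen on the core of compound 2 alone.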